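The compounds below may be only part of what the source reports. "The series", "measured", "known", "first", "only" and "open" are said of these compounds alone.

Compound 2 `O=C(/C(=C\c1ccc(Br)cc1)Sc1ccc(Br)cc1)c1ccc(Cl)cc1` gives 1000 nM in a functional assay on DU-145 cells (Homo sapiens) for inhibition, read by trypan blue exclusion, with a stated time of 96 h (a lower number here means a stronger inhibitor of growth, a higher number a weaker inhibitor of growth), level with compound 1 `O=C(/C(=C\c1ccc(Br)cc1)SCc1ccc(Cl)cc1)c1ccc(Cl)cc1` at 1000 nM at the digits shown, the two together being the lowest of the three numbers; compound 3 `Cc1ccc(CS/C(=C/c2ccc(Br)cc2)C(=O)c2ccc(Cl)cc2)cc1` gives 10000 nM. All three measured steps lie on the sulfur side of the shared core: no change at the digits printed from compound 1 to compound 2 (within the scatter), a 10-fold higher number from compound 2 to compound 3 (1.00 log units; beyond the scatter) and a 10-fold higher number from compound 1 to compound 3 (1.00 log units; beyond the scatter). Compound 4 `COc1ccccc1/C=C(/Sc1ccc(Br)cc1)C(=O)c1ccc(Cl)cc1` differs from compound 2 on the other side: 2-methoxyphenyl in place of 4-bromophenyl on a double-bonded chain carbon bound to a double-bonded chain carbon. For the measured compounds named here, no measured step touches that position, so these data offer no direct guide, and the expectation rests on the assumption that the sulfur-side pattern says nothing about this site. Compound 4 is therefore expected to differ little from its parent, the expected step being a 2.0-fold higher number from compound 2 to compound 4 (0.30 log units; within the scatter) with wide uncertainty. The estimate for compound 4 is 2000 nM, within 500 nM to 10000 nM.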

Compound 4, concentration for 50% growth inhibition: 10000 nM
For compound 4 the middle estimate is 5.0-fold (0.70 log units) below the measured one; the measured number falls inside the stated range.
By their numbers in this assay, from the lowest: compounds 1 and 2 (each within the scatter of the next); then compounds 3 and 4 (each within the scatter of the next).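

In this assay, the aryl group on the double-bonded chain carbon bound to a double-bonded chain carbon proves to matter: 2-methoxyphenyl in place of 4-bromophenyl gives a 10-fold higher number from compound 2 to compound 4 (1.00 log units; beyond the scatter), a step beyond the scatter. For the compounds shown here, the earlier compounds showed changes only on the sulfur side, so this is the first sign that the other side of the shared core also affects growth inhibition. Nothing measured here explains the step. On these data alone, whether the higher number follows the loss of the bromine or the arrival of the methoxy stays open. So does how a plain phenyl or a 4-aminophenyl would compare at this place.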